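The compounds below may be only part of what the source reports. "The series", "measured", "known", "first", "only" and "open" are said of these compounds alone.

In an ADME assay on MT4 cells (Homo sapiens) for cytotoxicity, read by MTT assay (a higher number here means that more compound is tolerated, a lower number that less compound is tolerated), compound 3 `COc1ccc(-n2ccnc2SCC(=O)Nc2ccccc2Cl)cc1` gives > 334000 nM, which is a limit of the assay and not a number. Compound 2 `COc1ccc(-n2ccnc2SCC(=O)Nc2ccccc2C)cc1` likewise reaches only a limit in this assay, namely > 353000 nM. Compound 1 `O=C(CSc1nccn1-c1ccc(Cl)cc1)Nc1ccccc1F` stops at a limit in this assay as well, > 345000 nM. With every value a limit (the limit of > 334000 nM in this assay, at which 1 of the 3 values shown sits, (the limit of > 345000 nM in this assay, at which 1 of the 3 values shown sits), (the limit of > 353000 nM in this assay, at which 1 of the 3 values shown sits)), compound 3 stands nowhere readable among them. Among the measured compounds shown here, the only measured step, a step that the two limits leave unreadable from compound 2 to compound 3, concerns a halogen change at the same place, but its size cannot be read. Compound 4 `COc1ccc(-n2ccnc2SCC(=O)Nc2ccccc2F)cc1` differs from compound 3 by fluoro in place of chloro on an aromatic carbon. For the measured compounds named here, no step of readable size bears on this change, so nothing beyond the scatter is expected. For compound 4 the expected step is a step that the limit leaves unreadable from compound 3 to compound 4. Compound 4 is expected to give 340000 nM in this assay, within 150000 nM to 450000 nM, most likely again only as a limit.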

Compound 4, half-maximal cytotoxic concentration: >= 41900 nM
Compound 4 ended at the assay's limit (the forecaster's own chance of this, stated with the estimate: 85%); the middle value does not contradict the limit.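

Compound 4 gives >= 41900 nM in this assay, which is a limit of the assay and not a number. Among the compounds shown here, compound 1, compound 2 and compound 3 also stand at limits, so no step among the four can be read. The compounds shown leave open whether changing the aromatic substituents alters tolerated concentration at all.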